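The compounds below may be only part of what the source reports. "The series", "measured", "known", "first", "only" and "open" are said of these compounds alone.

Three compounds share one core and differ in the chain carried on the nitrogen of the aromatic ring. Compound 1 `O=S(=O)(NCCCNc1nccc(-c2c(-c3cccc(F)c3)nc3sccn23)n1)c1ccc(Br)cc1` gives 7040 nM in a functional assay on A-375 cells (Homo sapiens) for cytotoxicity, read by MTT assay; a lower number here means a stronger inhibitor, a higher number a weaker inhibitor. Compound 2 `Cc1ccc(S(=O)(=O)NCCCNc2nccc(-c3c(-c4cccc(F)c4)nc4sccn34)n2)cc1` gives 8380 nM, and compound 3 `O=S(=O)(NCCNc1nccc(-c2c(-c3cccc(F)c3)nc3sccn23)n1)c1cccc(F)c1` gives 14900 nM. Compound 2 stands second highest of the three numbers; its nearest neighbour is compound 1, with a 1.2-fold higher number from compound 1 to compound 2 (0.08 log units; within the scatter), and its furthest is compound 3, with a 1.8-fold higher number from compound 2 to compound 3 (0.25 log units; within the scatter).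

Compound 4 `Cc1ccc(C(=O)NCCNc2nccc(-c3c(-c4cccc(F)c4)nc4sccn34)n2)cc1` is not yet measured. It differs from compound 2 in one place: ((4-methylphenyl)carbonyl)amino in place of (((4-methylphenyl)sulfonyl)amino)methyl on a saturated chain carbon, two bonds along the chain from a nitrogen on an aromatic ring. Among the measured compounds shown here, no measured step exchanges a sulfonyl for a carbonyl, so that part of the change has no precedent here. The chain is also shortened, as it is from compound 2 to compound 3 and from compound 1 to compound 3, where a 2.1-fold higher number from compound 1 to compound 3 (0.33 log units; beyond the scatter) was seen. Those steps were small and went toward higher numbers, so a small step in the same direction, or none beyond the scatter, is expected for compound 4 in this assay. Compound 4 is therefore estimated at 13000 nM, with a range from 5000 nM to 35000 nM, which would mean an expected 1.6-fold higher number from compound 2 to compound 4 (0.19 log units; within the scatter).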

Compound 4, half-maximal inhibitory concentration: 5880 nM
Estimate against measurement, compound 4: 2.2-fold (0.34 log units) above; the measured number falls inside the stated range.
By their numbers in this assay, from the lowest: compounds 4, 1, 2 and 3 (each within the scatter of the next, the first and the last beyond it).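

In this assay, ((4-methylphenyl)carbonyl)amino in place of (((4-methylphenyl)sulfonyl)amino)methyl gives a 1.4-fold lower number from compound 2 to compound 4 (0.15 log units; within the scatter) and the same exchange on the bromo-bearing chain gives a 1.2-fold lower number from compound 1 to compound 4 (0.08 log units; within the scatter) and so the shorter chain with a carbonyl stays level with both longer sulfonyl compounds. On the amine nitrogen, (4-methylphenyl)carbonyl in place of (3-fluorophenyl)sulfonyl gives a 2.5-fold lower number from compound 3 to compound 4 (0.40 log units; beyond the scatter) and shows that two compounds with the same shorter chain can still lie apart. No measurement shown here explains these numbers.

The compounds shown leave open whether that last step follows from the carbonyl or from the methyl and fluoro groups on the aromatic ring, which change along with it. As far as these compounds go, how a longer chain, or a plain amine in place of the carbonyl, would read in this assay also stays open.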